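The source may report more compounds than this note shows. Statements on the series, on what has been measured and on what is new or still open speak of the compounds shown alone.

Compound 2 `C#CCN(C)Cc1cccc(NC(=O)CCCCCCC(=O)NO)c1` carries its hydroxycarbamoyl group at the end of a saturated chain and, in a functional assay on PC-3 cells (Homo sapiens) for inhibition, read by MTT assay, with a stated time of 48 h (a lower number here means a stronger inhibitor of growth, a higher number a weaker inhibitor of growth), gives 330 nM. Among the compounds with values here, of the two compounds measured so far, compound 2 has the lowest number; the only other one, compound 1 `C#CCN(C)Cc1cccc(NC(=O)CCCCC(=O)NO)c1`, gives 5150 nM in this assay. Within the data shown here, the single measured step is a 16-fold lower number from compound 1 to compound 2 (1.19 log units; beyond the scatter), a lengthening of the chain that brought a sharp fall in the number. Compound 3 `C#CCN(C)Cc1cccc(NC(=O)CCCCCCCC(=O)NO)c1` lengthens the chain once more: (hydroxycarbamoyl)methyl in place of hydroxycarbamoyl on a saturated chain carbon, six bonds along the chain from a carbonyl carbon. The step from compound 1 to compound 2 bears on this change and was large, but a second lengthening of the same chain need not repeat a fall of that size. A smaller further fall, or no change beyond the scatter, is expected. Compound 3 is expected to give 200 nM, within a range of 70 nM to 600 nM, which corresponds to an expected step of a 1.7-fold lower number from compound 2 to compound 3 (0.22 log units; within the scatter).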

Compound 3, concentration for 50% growth inhibition: 4070 nM
Estimate against measurement, compound 3: 20-fold (1.31 log units) below; the whole stated range lies below it.
By their numbers in this assay, from the lowest: compound 2; then compounds 3 and 1 (each within the scatter of the next).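

The lengthening does not keep working in one direction: in this assay the further step gives a 12-fold higher number from compound 2 to compound 3 (1.09 log units; beyond the scatter) and so undoes the gain seen on the earlier lengthening. The comparison with the shortest chain gives a 1.3-fold lower number from compound 1 to compound 3 (0.10 log units; within the scatter) and places the two compounds level, so among these three chains compound 2 alone holds the low number, with a weaker compound on either side of it. Nothing shown here explains why such a small addition to the chain has so large an effect.

Going by these compounds, how the number behaves at chain lengths between those of compound 1 and compound 2, and with a longer chain than that of compound 3, remains open. So does whether a carboxylic acid at the chain end, in place of hydroxycarbamoyl, would follow the same pattern.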